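The source may hold more compounds than are shown below. What is called first, only, known or untested is meant among the compounds shown, and "the series" means these compounds.

Compound 2 `O=C(CSc1nc(Nc2ccccc2)c2ccccc2n1)Nc1ccccc1Br` belongs to a small set of three compounds built on one shared core, each differing only in the ring attached to the amide-type nitrogen. In a functional assay on NCI-H1975 cells (Homo sapiens) for inhibition, read by MTT assay, with a stated time of 72 h (a higher number here means a weaker inhibitor, a lower number a stronger inhibitor), compound 2 gives 10300 nM. Compound 1 `O=C(CSc1nc(Nc2ccccc2)c2ccccc2n1)Nc1ccccc1F` gives 9350 nM, and compound 3 `O=C(CSc1nc(Nc2ccccc2)c2ccccc2n1)Nc1cccc(Br)c1` gives 10100 nM. Compound 2 has the highest number of the three, but the steps of a 1.1-fold higher number from compound 1 to compound 2 (0.04 log units; within the scatter) and a 1.0-fold lower number from compound 2 to compound 3 (0.01 log units; within the scatter) both sit within the scatter, as does a 1.1-fold higher number from compound 1 to compound 3 (0.03 log units; within the scatter), so the three compounds cannot be told apart on these measurements.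

Compound 4 `C=CC(=O)Nc1cccc(NC(=O)CSc2nc(Nc3ccccc3)c3ccccc3n2)c1` takes the step from compound 2 described as 3-((vinylcarbonyl)amino)phenyl in place of 2-bromophenyl on an amide-type nitrogen. For the measured compounds named here, no measured step adds a group of this kind; the closest comparison is a 1.0-fold lower number from compound 2 to compound 3 (0.01 log units; within the scatter), where moving a bromine on the ring changed nothing beyond the scatter. With nothing in the data pointing either way, compound 4 is expected to show a 1.3-fold lower number from compound 2 to compound 4 (0.11 log units; within the scatter), no step beyond the scatter, though the uncertainty is large. Compound 4 is therefore estimated at 8000 nM, within a range from 1500 nM to 40000 nM.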

Compound 4, half-maximal inhibitory concentration: 8120 nM
Compound 4: middle estimate off by 1.0-fold (0.01 log units), on the low side, within the range that was stated.
By their numbers in this assay, from the lowest: compounds 4, 1, 3 and 2 (each within the scatter of the next).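

Until now, the ring on the amide-type nitrogen had carried only a single halogen. Compound 4 shows that this place also tolerates a larger group, 3-((vinylcarbonyl)amino)phenyl, which brings a hydrogen-bond donor and acceptor, with no step beyond the scatter in this assay: the steps are a 1.3-fold lower number from compound 2 to compound 4 (0.10 log units; within the scatter) and a 1.2-fold lower number from compound 3 to compound 4 (0.09 log units; within the scatter) and a 1.2-fold lower number from compound 1 to compound 4 (0.06 log units; within the scatter), so compound 4 cannot be told apart from the three halogen compounds. No other data here bear on this result.

Going by these compounds, what stays open is whether any change on this ring can move the number beyond the scatter, and whether the double bond of the new group matters at all. A ring carrying an amine or a carboxylic acid, or a saturated propanoylamino group in place of the (vinylcarbonyl)amino group, would address these questions.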